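The source may hold more compounds than are shown below. What is called first, only, known or untested is meant among the compounds shown, and "the series" means these compounds.

Compound 2 `O=C(NCc1ccc(CNS(=O)(=O)c2ccc3c(c2)CCO3)cc1)c1cccnc1` gives 1000 nM in an assay on cells for displacement of a labelled ligand from C-X-C chemokine receptor type 4 (Homo sapiens), read by fluorescence and microscopy, with stated times of 10 min and 30 min (a higher number here means that more compound is needed for the effect, a lower number that less compound is needed), level with compound 1 `Cc1cc(C(=O)NCc2ccc(CNS(=O)(=O)c3ccc4c(c3)CCO4)cc2)n(C)n1`, which gives 1000 nM in this assay. Within the data shown here, the only measured step, no change at the digits printed from compound 1 to compound 2 (within the scatter), shows that swapping one aromatic group on the carbonyl carbon left the read-out unchanged within the scatter. Compound 3 `O=C(NCc1ccc(CNS(=O)(=O)c2ccc3c(c2)CCO3)cc1)c1cc2ccccn2n1` carries a group of 9 heavy atoms (7 carbon, 2 nitrogen; one five-membered aromatic ring with 2 hetero atoms, one six-membered aromatic ring with 1 hetero atom) in place of a group of 6 heavy atoms (5 carbon, 1 nitrogen; one six-membered aromatic ring with 1 hetero atom), on a carbonyl carbon. Among the measured compounds shown here, since the one comparable exchange at this carbonyl carbon, no change at the digits printed from compound 1 to compound 2 (within the scatter), was flat, no step beyond the scatter is expected for compound 3, so no change at the digits printed from compound 2 to compound 3 (within the scatter) is the estimated shift. Compound 3 is therefore expected to give about 1000 nM, between 300 nM and 3000 nM.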

Compound 3, effective concentration (reported as EC, without a stated level of effect): 1 nM
Beside the measured number, compound 3's estimate is 1000-fold (3.00 log units) above it; measured number below the stated range.
By their numbers in this assay, from the lowest: compound 3; then compounds 1 and 2 (each within the scatter of the next).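

At this carbonyl carbon, the read-out in this assay proves highly sensitive to the aromatic group: there is a 1000-fold lower number from compound 2 to compound 3 (3.00 log units; beyond the scatter), and also a 1000-fold lower number from compound 1 to compound 3 (3.00 log units; beyond the scatter). The exchange between pyridin-3-yl and 1,3-dimethyl-1H-pyrazol-5-yl had given no hint of this, and only the entering group combines a five-membered and a six-membered aromatic ring. Nothing available bears on why the number falls so far. The compounds shown leave open whether both rings of the entering group are needed, and whether adding an amine or a carboxylic acid to that group would keep the low number.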